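Aryl Substitution and Nucleoside Transporter Inhibition

The source may hold more compounds than are shown below. What is called first, only, known or untested is meant among the compounds shown, and "the series" means these compounds.

Measured compounds:
compound 1 `OC[C@H]1O[C@@H](n2cnc3c(SCc4ccccc4Br)ncnc32)[C@H](O)[C@@H]1O`: 151 nM
compound 2 `Cc1cccc(CSc2ncnc3c2ncn3[C@@H]2O[C@H](CO)[C@@H](O)[C@H]2O)c1`: 16.2 nM

In an assay on isolated protein for inhibition of Equilibrative nucleoside transporter 1 (Homo sapiens) (on this read-out lower numbers stand for stronger inhibition and higher numbers for weaker inhibition), compound 2 gives the lowest of the two numbers; compound 1 sits a 9.3-fold lower number from compound 1 to compound 2 (0.97 log units; beyond the scatter) away. Compound 3 `Cc1cc(C)c(CSc2ncnc3c2ncn3[C@@H]2O[C@H](CO)[C@@H](O)[C@H]2O)c(C)c1` differs from compound 2 by 2,4,6-trimethylphenyl in place of 3-methylphenyl on a saturated chain carbon bound to a sulfur. For the measured compounds named here, the only step that bears on it is a 9.3-fold lower number from compound 1 to compound 2 (0.97 log units; beyond the scatter), in which 2-bromophenyl gave the higher number. With two further methyl groups on the ring, compound 3 is expected to show a modest rise in this assay, a 2.5-fold higher number from compound 2 to compound 3 (0.39 log units; beyond the scatter), estimated at 40 nM within 10 nM to 160 nM.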

Compound 3, inhibition constant: 1910 nM
Compound 3: middle estimate off by 48-fold (1.68 log units), on the low side; measured number above the stated range.
By their numbers in this assay, from the lowest: compound 2; then compound 1; then compound 3.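

Replacing 3-methylphenyl with 2,4,6-trimethylphenyl gives a 120-fold higher number from compound 2 to compound 3 (2.07 log units; beyond the scatter) in this assay and shows that this place, on a saturated chain carbon bound to a sulfur, responds far more sharply to ring substitution than the first step suggested. Set against 2-bromophenyl, the same group gives a 13-fold higher number from compound 1 to compound 3 (1.10 log units; beyond the scatter) and so places compound 3 behind both earlier compounds. No measurement here accounts for this rise.

From the compounds shown here alone, whether a single added methyl group would produce such a rise stays open, as does how a phenyl ring carrying an amine or a methoxy group would read at this place.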